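This account rests on a few compounds, and the source may have more. Where it says the series, first, only, none or still open, it means among the compounds named here.

In a functional assay on V79 cells (Cricetulus griseus) for cytotoxicity, read by colony formation (on this read-out lower numbers stand for stronger inhibition and higher numbers for weaker inhibition), compound 3 `CC1CN(c2c(F)cc3c(=O)c(C(=O)O)cn(C4CC4)c3c2C(F)(F)F)CC(C)N1` gives > 500 ug/mL, which is a limit of the assay and not a number. Two relatives with the same core have numbers: compound 1 `O=C(O)c1cn(C2CC2)c2c(C(F)(F)F)c(N3CCCC3)c(F)cc2c1=O` gives 280 ug/mL and compound 2 `CC1(CN)CCN(c2c(F)cc3c(=O)c(C(=O)O)cn(C4CC4)c3c2C(F)(F)F)C1` gives 110 ug/mL. Compound 4 `CC1CN(c2c(F)cc3c(=O)c(C(=O)O)cn(C4CC4)c3c2C(F)(F)F)CCN1` differs from compound 3 in one place: hydrogen in place of methyl on a saturated ring carbon. This is hydrogen in place of methyl on a saturated ring carbon, so 3,5-dimethylpiperazin-1-yl becomes 3-methylpiperazin-1-yl.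

Going by the values given here, no measured step removes a single methyl, so the nearest guides are steps that swap the whole ring group. These are an at least 1.7-fold higher number from compound 1 to compound 3 (0.25 log units; that floor lies within the scatter) and an at least 4.5-fold higher number from compound 2 to compound 3 (0.65 log units; beyond the scatter). Both run towards higher numbers on reaching compound 3, though only the second clearly exceeds the scatter. Losing one methyl is a smaller change than either swap, so a modest move back is the reasonable expectation. The expected change is an at least 1.6-fold lower number from compound 3 to compound 4 (0.22 log units; that floor lies within the scatter), towards stronger inhibition in this assay. For compound 4 the estimated value is 300 ug/mL, with an expected range from 130 ug/mL to 500 ug/mL.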

Compound 4, half-maximal inhibitory concentration: 220 ug/mL
Estimate against measurement, compound 4: 1.4-fold (0.13 log units) above; low and high end bracket the measured number.
By their numbers in this assay, from the lowest: compounds 2, 4 and 1 (each within the scatter of the next, the first and the last beyond it). At a limit, above all of these: compound 3.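

Compounds 1, 2 and 3 compared only whole ring groups, whereas here a single methyl on a saturated ring carbon, next to the ring nitrogen, is changed on its own: in this assay, hydrogen in its place gives an at least 2.2-fold lower number from compound 3 to compound 4 (0.35 log units; beyond the scatter). With 3-methylpiperazin-1-yl in place of 3,5-dimethylpiperazin-1-yl, the new compound cannot be told apart from the other two relatives, as the steps show a 2.0-fold higher number from compound 2 to compound 4 (0.30 log units; within the scatter) and a 1.3-fold lower number from compound 1 to compound 4 (0.10 log units; within the scatter). The step from the dimethyl compound gives only a floor for the change, because compound 3 stands at a limit of the assay: the limit of > 500 ug/mL in this assay, at which 1 of the 4 values shown sits.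

On these data alone, it remains open whether hydrogen in place of the remaining methyl would shift the number further in this assay. An ethyl group or a hydroxymethyl group on this ring carbon is also an open case.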